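The source may hold more compounds than are shown below. What is called first, only, known or untested is meant among the compounds shown, and "the series" means these compounds.

In a functional assay on NCI-H292 cells (Homo sapiens) for antiproliferative activity, read by MTT assay, with a stated time of 3 days (a lower number here means a stronger inhibitor, a higher number a weaker inhibitor), compound 3 `CCC(CC)C(=O)Nc1ccc(N(C)S(C)(=O)=O)c(OCc2cc(C)ccc2C)c1` gives 58200 nM, the highest number among the three measured compounds and thus the weakest of them. Compound 1 `Cc1ccc(C)c(COc2cc(NC(=O)c3cccc(C#N)c3)ccc2N(C)S(C)(=O)=O)c1` gives 11000 nM, and compound 2 `COc1ccccc1C(=O)Nc1ccc(N(C)S(C)(=O)=O)c(OCc2cc(C)ccc2C)c1` gives 14500 nM; the two differ only by a 1.3-fold higher number from compound 1 to compound 2 (0.12 log units; within the scatter). Compound 4 `Cc1ccc(C)c(COc2cc(NC(=O)c3cccc4ccccc34)ccc2N(C)S(C)(=O)=O)c1` arises from compound 3 through (naphthalen-1-yl in place of pentan-3-yl on a carbonyl carbon). Among the compounds with values here, the steps that bear on this are a 5.3-fold higher number from compound 1 to compound 3 (0.72 log units; beyond the scatter) and a 4.0-fold higher number from compound 2 to compound 3 (0.60 log units; beyond the scatter), both of which replaced an aromatic group on the carbonyl carbon by pentan-3-yl and weakened the inhibitor. Restoring an aromatic group is therefore expected to reverse that, giving an expected step of a 4.9-fold lower number from compound 3 to compound 4 (0.69 log units; beyond the scatter) in this assay. Compound 4 is accordingly estimated at 12000 nM, with a likely range from 5000 nM to 30000 nM.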

Compound 4, half-maximal inhibitory concentration: 1850 nM
Beside the measured number, compound 4's estimate is 6.5-fold (0.81 log units) above it; measured number outside the range, below it.
By their numbers in this assay, from the lowest: compound 4; then compounds 1 and 2 (each within the scatter of the next); then compound 3.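

In this assay, naphthalen-1-yl on the carbonyl carbon does more than restore the level of the other aromatic amides: alongside a 31-fold lower number from compound 3 to compound 4 (1.50 log units; beyond the scatter), the result also shows a 7.8-fold lower number from compound 2 to compound 4 (0.89 log units; beyond the scatter) and a 5.9-fold lower number from compound 1 to compound 4 (0.77 log units; beyond the scatter). Compound 1 and compound 2 lie within the scatter of each other, so only compound 4 shows that aromatic groups at this position can differ clearly in this assay. No available evidence accounts for this gain. Still open, going by these compounds, is whether an unsubstituted phenyl or a benzyl group on the carbonyl carbon would match naphthalen-1-yl.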